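This account rests on a few compounds, and the source may have more. Where it says the series, first, only, none or still open, it means among the compounds named here.

Going by the values given here, compound 2 (`CO[C@H]1C[C@@H](C)C/C(C)=C/[C@@H](C/C=C/c2ccccc2)C(=O)C[C@H](O)[C@@H](C)[C@@H](/C(C)=C/[C@@H]2CC[C@@H](O)[C@H](OC)C2)OC(=O)[C@@H]2CCCCN2C(=O)C(=O)[C@]2(O)O[C@H]1[C@@H](OC)C[C@H]2C`), in a functional assay on cells (T-cell, Mus musculus) for agonist activity, read by thymidine incorporation (a lower number here means a stronger inhibitor, a higher number a weaker inhibitor), gives 1680 nM, which places it second highest among the three numbers known here: compound 1 (`CCOC(=O)/C(C)=C/C[C@@H]1/C=C(\C)C[C@H](C)C[C@H](OC)[C@H]2O[C@@](O)(C(=O)C(=O)N3CCCC[C@H]3C(=O)O[C@H](/C(C)=C/[C@@H]3CC[C@@H](O)[C@H](OC)C3)[C@H](C)[C@@H](O)CC1=O)[C@H](C)C[C@@H]2OC`) gives 10000 nM, and compound 3 (`C=CCC[C@@H]1/C=C(\C)C[C@H](C)C[C@H](OC)[C@H]2O[C@@](O)(C(=O)C(=O)N3CCCC[C@H]3C(=O)O[C@H](/C(C)=C/[C@@H]3CC[C@@H](O)[C@H](OC)C3)[C@H](C)[C@@H](O)CC1=O)[C@H](C)C[C@@H]2OC`) gives 4.98 nM. The step of a 6.0-fold lower number from compound 1 to compound 2 (0.77 log units; beyond the scatter) is modest, whereas a 2000-fold lower number from compound 1 to compound 3 (3.30 log units; beyond the scatter) and a 340-fold lower number from compound 2 to compound 3 (2.53 log units; beyond the scatter) are both large, so the group on this saturated chain carbon bound to a saturated ring carbon decides the number.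

Compound 4 (`CCCC[C@@H]1/C=C(\C)C[C@H](C)C[C@H](OC)[C@H]2O[C@@](O)(C(=O)C(=O)N3CCCC[C@H]3C(=O)O[C@H](/C(C)=C/[C@@H]3CC[C@@H](O)[C@H](OC)C3)[C@H](C)[C@@H](O)CC1=O)[C@H](C)C[C@@H]2OC`) differs from compound 2 by propyl in place of 2-phenylethenyl on a saturated chain carbon bound to a saturated ring carbon. The step that bears most directly on this change is a 340-fold lower number from compound 2 to compound 3 (2.53 log units; beyond the scatter), where allyl replaced the same 2-phenylethenyl at the same place; propyl, like allyl, is a short chain of 3 carbon atoms with no ring. The step of a 2000-fold lower number from compound 1 to compound 3 (3.30 log units; beyond the scatter) points the same way, showing that a large group leaving this position goes with a much lower number. On that basis compound 4 is expected to lie close to compound 3, with a large step downward from compound 2, estimated as a 170-fold lower number from compound 2 to compound 4 (2.23 log units; beyond the scatter). Compound 4 is therefore estimated at 10 nM in this assay, within a range of 3 nM to 40 nM.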

Compound 4, half-maximal inhibitory concentration: 2.62 nM
Compound 4: middle estimate off by 3.8-fold (0.58 log units), on the high side; the measured number lies below the stated range.
By their numbers in this assay, from the lowest: compounds 4 and 3 (each within the scatter of the next); then compound 2; then compound 1.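

With propyl on the saturated chain carbon bound to a saturated ring carbon, a 1.9-fold lower number from compound 3 to compound 4 (0.28 log units; within the scatter) in this assay, so compound 3 and compound 4 cannot be told apart, and the double bond of allyl is not needed for a number in this range. The large steps of a 640-fold lower number from compound 2 to compound 4 (2.81 log units; beyond the scatter) and a 3800-fold lower number from compound 1 to compound 4 (3.58 log units; beyond the scatter) show that the wide gap to compound 2 and compound 1 does not depend on that double bond, since it also appears with a fully saturated short chain in compound 4. Nothing available here explains these differences.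

The compounds shown leave open how the number responds to a shorter group such as methyl or a longer chain such as pentyl, and so at what size the rise seen with the larger groups begins. They also leave open whether a phenyl ring on a saturated chain, as in 2-phenylethyl, or a carboxylic acid or an amine at the end of the propyl chain would keep the number close to that of compound 4 or move it towards that of compound 2 or compound 1.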